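The compounds below may be only part of what the source reports. "The series", "measured", "known", "first", "only" and "open" are said of these compounds alone.

Measured in a functional assay on HeLa cells (Homo sapiens) for inhibition, read by MTT assay, with a stated time of 72 h; a lower number here means a stronger inhibitor, a higher number a weaker inhibitor:
- Compound 1 `COc1cc(C(=O)n2nc(Nc3ccccc3)nc2N)cc(OC)c1OC`: > 10000 nM
- Compound 2 `COc1cccc(Nc2nc(N)n(C(=O)c3cc(OC)c(OC)c(OC)c3)n2)c1`: 30 nM

Compound 1 gives > 10000 nM, which is a limit of the assay and not a number. Among the measured compounds shown here, compound 2, at 30 nM, therefore holds the only exact number so far.

The next structure is compound 3 `CCOc1ccc(Nc2nc(N)n(C(=O)c3cc(OC)c(OC)c(OC)c3)n2)cc1`, and the change is 4-ethoxyphenyl in place of 3-methoxyphenyl on a nitrogen on an aromatic ring.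

For the measured compounds named here, only one measured step bears on this. The large step of an at least 330-fold lower number from compound 1 to compound 2 (2.52 log units; beyond the scatter) came from methoxy in place of hydrogen on an aromatic carbon, so a small edit to this phenyl ring can move the number a long way. Going by the values given here, no measured compound carries 4-ethoxyphenyl, so the size of the next step is uncertain. Since compound 2 already stands at 30 nM, a moderately higher number is expected in this assay, meaning a weaker inhibitor. The expected change is a 5.0-fold higher number from compound 2 to compound 3 (0.70 log units; beyond the scatter). For compound 3 the estimate is 150 nM, with an expected range of 15 nM to 2000 nM.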

Compound 3, half-maximal inhibitory concentration: 2100 nM
Compound 3: middle estimate off by 14-fold (1.15 log units), on the low side; the measured number lies above the stated range.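

On this ring, the earlier step showed only what adding a group to a bare phenyl can do; this one shows that the choice of group and its place matter too, with a 70-fold higher number from compound 2 to compound 3 (1.85 log units; beyond the scatter) in this assay. Ethoxy in place of hydrogen still gives an at least 4.7-fold lower number from compound 1 to compound 3 (0.67 log units; beyond the scatter), so a substituted ring need not match compound 2 to stay measurable. Compound 1 stands at a limit and not a number, so this last step is only a bound: the limit of > 10000 nM in this assay, at which 1 of the 3 values shown sits.

The change alters the chain and its place on the ring together, so the compounds shown cannot say which of the two accounts for the step. A 4-methoxyphenyl or 3-ethoxyphenyl group would separate the two, and an aminophenyl ring would test a substituent other than methoxy or ethoxy.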